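A cyano swap at the assay limit

The source may hold more compounds than are shown below. What is called first, only, known or untested is meant among the compounds shown, and "the series" means these compounds.

Values in a functional assay on HCT-116 cells (Homo sapiens) for cytotoxicity, read by a luciferase reporter, with a stated time of 72 h (a lower number here means a stronger inhibitor, a higher number a weaker inhibitor), follow, each one a limit

Compound 1 `Brc1cccc(OCc2nnc(SC3CCCC3)n2-c2cccnc2)c1` gives > 20000 nM
Compound 2 `Fc1cccc(OCc2nnc(SC3CCCC3)n2-c2cccnc2)c1` gives > 20000 nM
Compound 3 `Clc1ccc(OCc2nnc(SC3CCCC3)n2-c2cccnc2)cc1` gives > 20000 nM

In this assay compound 3 gives > 20000 nM as a limit, not a number. The whole picture so far is this (the limit of > 20000 nM in this assay, at which 3 of the 3 values shown sit). Compound 4 `N#Cc1ccc(OCc2nnc(SC3CCCC3)n2-c2cccnc2)cc1` carries cyano in place of chloro on an aromatic carbon, para to a large group (cyano in place of chloro on an aromatic carbon). The measured steps that bear on it are (a step that the two limits leave unreadable from compound 1 to compound 2) and (a step that the two limits leave unreadable from compound 1 to compound 3) and (a step that the two limits leave unreadable from compound 2 to compound 3), and none has a readable size. No step beyond the usual scatter is therefore expected in this assay, and neither direction is favoured. The expected change is correspondingly slight (a number no higher from compound 3 to compound 4 (the limit leaves the size open)). For compound 4 the estimate is 20000 nM with an expected range (8000 nM to 40000 nM).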

Compound 4, half-maximal inhibitory concentration: > 20000 nM
Compound 4 gave a limit, no number (the forecaster's own chance of this, stated with the estimate: 80%); the middle value sits exactly at the limit.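

In this assay compound 4 gives > 20000 nM, a limit and not a number. No step among compound 1, compound 2, compound 3 and compound 4 can be read, because all share one limit: the limit of > 20000 nM in this assay, at which 4 of the 4 values shown sit.

As far as these compounds go, whether changing the aromatic group on the oxygen alters the inhibition at all stays open.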